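This account rests on a few compounds, and the source may have more. Where it says the series, first, only, none or still open, it means among the compounds named here.

Of the compounds shown here, two have been measured in a functional assay on NCI-H460 cells (Homo sapiens) for antiproliferative activity, read by sulforhodamine B assay, with a stated time of 48 h; on this read-out lower numbers stand for stronger inhibition of growth and higher numbers for weaker inhibition of growth. Compound 1 `Cc1nc(SCC(=O)Nc2nc(-c3ccc(Cl)cc3)cs2)n(Nc2ccccc2)c1C` gives 11000 nM, and compound 2 `Cc1ccc(Nn2c(SCC(=O)Nc3nc(-c4ccccc4)cs3)nc(C)c2C)cc1` gives 16500 nM. These two numbers lie within the scatter of each other, so neither compound can be called the more potent. Compound 3 `COc1ccc(Nn2c(SCC(=O)Nc3nc(-c4ccc(Cl)cc4)cs3)nc(C)c2C)cc1` has not yet been measured. It differs from compound 1 by methoxy in place of hydrogen on an aromatic carbon. Among the compounds with values here, no measured pair isolates this change, so nothing beyond the scatter is expected in either direction. The expected step is a 1.1-fold higher number from compound 1 to compound 3 (0.04 log units; within the scatter). Compound 3 is therefore estimated at 12000 nM in this assay, within a range from 5000 nM to 30000 nM.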

Compound 3, concentration for total growth inhibition: 10600 nM
The estimate for compound 3 lay 1.1-fold (0.05 log units) above the measured number; low and high end bracket the measured number.
By their numbers in this assay, from the lowest: compounds 3, 1 and 2 (each within the scatter of the next).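

Turning the phenyl into 4-methoxyphenyl gives a 1.0-fold lower number from compound 1 to compound 3 (0.02 log units; within the scatter) in this assay. Within the data shown here, this is the first direct reading of this position: it takes a methoxy group, with its added oxygen and carbon, with no change that can be told apart from the scatter. Nothing shown offers an explanation for this result. Still open, from the compounds shown here alone, is whether an amine, a carboxylic acid or a longer alkoxy chain at the same place would move the number beyond the scatter. Also open, going by these compounds, is whether methoxy elsewhere on this ring would behave the same way.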